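This account rests on a few compounds, and the source may have more. Where it says the series, first, only, none or still open, it means among the compounds named here.

Compound 1 `CCCCN(CC)c1cc(C)nc2c1NC(=O)CN2c1ccc(C(C)(C)C)cc1Br`: in an assay on HEK-293T cells for displacement of a labelled ligand from corticotropin-releasing factor receptor 1 (Homo sapiens), read by scintillation counting, with a stated time of 2 h (on this read-out higher numbers stand for weaker inhibition and lower numbers for stronger inhibition), compound 1 gives 4.2 nM.
Compound 2 `CCCN(CCC)c1cc(C)nc2c1NC(=O)CN2c1ccc(C(C)C)cc1Br`: compound 2 gives 3.1 nM.
Compound 3 `CCCCN(CC)c1cc(C)nc2c1NC(=O)CN2c1ccc(Cl)cc1Br`: compound 3 gives 2.5 nM.

Compound 3 has the lowest of the three numbers, but its separation from compound 2 and from compound 1 lies within the scatter, so no order among the three can be claimed. Going by the values given here, the only single-place step measured, a 1.7-fold lower number from compound 1 to compound 3 (0.23 log units; within the scatter), concerns the chloro group. Compound 4, `CCCCN(CC)c1cc(C)nc2c1NC(=O)CN2c1ccc(Cl)cc1C`, differs from compound 3 elsewhere: methyl in place of bromo on an aromatic carbon. Among the compounds with values here, no measured step touches this position; the step from compound 1 to compound 3 shows only that a change on this ring left the number within the scatter. Compound 4 is therefore expected to stay close to compound 3. The expected step is a 2.0-fold higher number from compound 3 to compound 4 (0.30 log units; within the scatter), within the scatter. The estimate for compound 4 is 5 nM, ranging from 1.5 nM to 17 nM.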

Compound 4, inhibition constant: 5.4 nM
Estimate against measurement, compound 4: 1.1-fold (0.03 log units) below; the measured number falls inside the stated range.
By their numbers in this assay, from the lowest: compounds 3, 2, 1 and 4 (each within the scatter of the next, the first and the last beyond it).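

This position, ortho to a large group, had not been touched by any earlier step, and the first change there, methyl in place of bromo, gives a modest step in this assay: a 2.2-fold higher number from compound 3 to compound 4 (0.33 log units; beyond the scatter). Unlike the step from the earlier compounds, this one lies beyond the scatter, although one heavy atom replaces one heavy atom. Going by these compounds, whether methoxy, fluoro or an amine at this position would give a lower or a higher number remains open. Nothing measured here accounts for the step.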